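Compound 3: a hydrazone change on an inactive pair

The compounds below may be only part of what the source reports. "The series", "measured", "known", "first", "only" and "open" are said of these compounds alone.

In a functional assay on ECa-109 cells (Homo sapiens) for antiproliferative activity, read by MTT assay, with a stated time of 72 h (a higher number here means a weaker inhibitor, a lower number a stronger inhibitor), compound 1 `CCCSc1nc(N/N=C/c2ccc(C)cc2)c2nnn(Cc3ccccc3)c2n1` gives > 64000 nM, which is a limit and not a number. Compound 2 `CCCSc1nc(N/N=C/c2cccnc2)c2nnn(Cc3ccccc3)c2n1` gives > 64000 nM in this assay, again only a limit. Compound 2 therefore has no numerical standing, and the pair sits together at the limit of > 64000 nM in this assay, at which 2 of the 2 values shown sit.

The next compound is compound 3 `CCCSc1nc(N/N=C(\C)c2ccc(O)cc2)c2nnn(Cc3ccccc3)c2n1`. The change from compound 2 is a group of 10 heavy atoms (8 carbon, 1 nitrogen, 1 oxygen; one six-membered aromatic ring of carbon only) in place of a group of 8 heavy atoms (6 carbon, 2 nitrogen; one six-membered aromatic ring with 1 hetero atom), on a nitrogen on an aromatic ring. One six-membered aromatic ring of carbon only now stands in place of one six-membered aromatic ring with 1 hetero atom, on a nitrogen on an aromatic ring.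

Among the measured compounds shown here, only one measured step bears on this change: a step that the two limits leave unreadable from compound 1 to compound 2. Its size cannot be read, so it offers no size to carry over. The expectation in this assay is no clear change from the limit, with some chance of a move towards stronger inhibition. The expected step is an at least 1.4-fold lower number from compound 2 to compound 3 (0.15 log units; that floor lies within the scatter). For compound 3 the estimated value is 45000 nM, with an expected range of 10000 nM to 64000 nM.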

Compound 3, half-maximal inhibitory concentration: 32500 nM
Compound 3: the middle estimate sits 1.4-fold (0.14 log units) above what was measured; low and high end bracket the measured number.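

In this assay, among the compounds shown here, compound 3 is the first to give a number and not a limit, so this place, on a nitrogen on an aromatic ring, now has readable steps: an at least 1.9-fold lower number from compound 2 to compound 3 (0.29 log units; that floor lies within the scatter), and an at least 1.9-fold lower number from compound 1 to compound 3 (0.29 log units; that floor lies within the scatter). For the compounds shown here, both are floors that lie within the scatter, so they show only that a change in this group can bring a value under the limit of the assay, not that a real gain of any given size exists. Compound 1 also carries a six-membered aromatic ring of carbon only, so the kind of ring alone does not set compound 3 apart, and the other compounds remain limits and not numbers: the limit of > 64000 nM in this assay, at which 2 of the 3 values shown sit.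

The group that enters in compound 3 differs from those in compound 1 and compound 2 as a whole, so the compounds shown do not tell which part of it goes with the lower number. From the compounds shown here alone, whether an amine or a carboxylic acid on the aromatic ring of this group, or a longer chain in the same place, would give a step clearly beyond the scatter remains open.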